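This account rests on a few compounds, and the source may have more. Where it says the series, first, only, none or still open, it means among the compounds named here.

Compound 1 `Oc1cccc(-c2cc(-c3cccc(Cl)c3)nc(-c3ccco3)c2)c1`, compound 2 `Oc1ccc(-c2cc(-c3ccncc3)nc(-c3cccc(Cl)c3)c2)cc1` and compound 3 `Oc1ccc(-c2cc(-c3cccc(Cl)c3)nc(-c3ccco3)c2)cc1` share one core and differ in the aryl groups set around it. In a functional assay on T47D cells (Homo sapiens) for cytotoxicity, read by CCK-8 assay and cell counting, with a stated time of 2 days (a lower number here means a stronger inhibitor, a higher number a weaker inhibitor), compound 1 gives 3570 nM. For compound 2 the same assay records "not determined" (no result reported), so compound 2 stands nowhere on the scale shown here; it has only a structure. The step from compound 2 to compound 3 is furan-2-yl in place of pyridin-4-yl on an aromatic carbon, which is furan-2-yl in place of pyridin-4-yl on an aromatic carbon. Going by the values given here, no measured step in this assay describes such a change, and compound 2 gives no starting value, so the size and direction of the step cannot be read from the data; anything from a small shift within the scatter to a larger move in either direction remains open. The estimate for compound 3 in this assay therefore rests on compound 1, which gives 3570 nM, and compound 3 is expected near 4000 nM, within a range from 1000 nM to 20000 nM.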

Compound 3, half-maximal inhibitory concentration: 5220 nM
Beside the measured number, compound 3's estimate is 1.3-fold (0.12 log units) below it, and the stated range covers the measured number.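

In this assay, going by these compounds alone, the exchange of 3-hydroxyphenyl for 4-hydroxyphenyl on the shared core gives a 1.5-fold higher number from compound 1 to compound 3 (0.17 log units; within the scatter) and so is the first change in this set that can be read from two numbers. On this evidence the assay does not separate the two hydroxyphenyl groups, and the pair, with the furan-2-yl and 3-chlorophenyl groups held fixed in both compounds, shows that this one move of the hydroxyl leaves the result within the scatter. The remaining step, furan-2-yl in place of pyridin-4-yl, still cannot be read, and no measurement shown here accounts for the outcome of the hydroxyl move.

The compounds shown leave open whether the hydroxyl matters at all, since every one of them carries it on its phenyl ring, and an amine or a carboxylic acid in its place would bear on that. From the compounds shown here alone, it also remains open how far the result in this assay depends on the 3-chlorophenyl group, which a plain phenyl or a 3-methoxyphenyl group could address.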